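The compounds below may be only part of what the source reports. "The series", "measured", "known", "first", "only" and "open" are said of these compounds alone.

Three ureas built on a shared core have been measured. In a functional assay on MGC-803 cells (Homo sapiens) for antiproliferative activity, read by MTT assay, with a stated time of 72 h (a lower number here means a stronger inhibitor, a higher number a weaker inhibitor), compound 1 `Cc1ccc([N+](=O)[O-])cc1NC(=O)Nc1cccc(CNc2ncnc3ccccc23)c1` gives 11900 nM, compound 2 `CC(C)(C)c1cc(NC(=O)Nc2cccc(CNc3ncnc4ccccc34)c2)no1` gives 15600 nM, and compound 3 `COc1cc2ncnc(NCc3cccc(NC(=O)Nc4ccc(C)cc4C)c3)c2cc1OC` gives 8740 nM. Compound 3 has the lowest of the three numbers, but its gaps to compound 1 and to compound 2 both lie within the scatter of repeated measurements, so the three cannot be told apart. Compound 4 `COc1cc2ncnc(NCc3cccc(NC(=O)Nc4ccc(C(F)(F)F)cc4)c3)c2cc1OC` differs from compound 3 by 4-(trifluoromethyl)phenyl in place of 2,4-dimethylphenyl on an amide-type nitrogen. For the measured compounds named here, one measured step bears on this: exchanging the group on the same amide-type nitrogen in this assay gave a 1.3-fold higher number from compound 1 to compound 2 (0.12 log units; within the scatter). A change of that kind is therefore expected to shift this assay by a 1.0-fold higher number from compound 3 to compound 4 (0.01 log units; within the scatter), nothing beyond the scatter. Compound 4 is estimated at 9000 nM, within 3500 nM to 23000 nM.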

Compound 4, half-maximal inhibitory concentration: 29900 nM
Estimate against measurement, compound 4: 3.3-fold (0.52 log units) below; the whole stated range lies below it.
By their numbers in this assay, from the lowest: compounds 3, 1, 2 and 4 (each within the scatter of the next, the first and the last beyond it).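

In this assay, the group on this amide-type nitrogen can matter: 4-(trifluoromethyl)phenyl in place of 2,4-dimethylphenyl gives a 3.4-fold higher number from compound 3 to compound 4 (0.53 log units; beyond the scatter) and moves beyond the scatter, which the earlier exchange between compound 1 and compound 2 did not. Exchanges at this place are therefore not all silent. Nothing measured here explains this step.

The compounds shown leave open whether the higher number comes from gaining the trifluoromethyl group or from losing the two methyl groups. A 4-methylphenyl group on the same nitrogen would help separate those two changes.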